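A few compounds are considered here, and "the series" means these few. Any claim that something is new, unique, unknown or untested is made for them only; others in the source may bear on it.

Going by the values given here, compound 2 `Cc1ccc(S(=O)(=O)N(Cc2nnc(Cc3cccc(F)c3)o2)c2cccc(Cl)c2C)cc1` gives 501 nM in a functional assay on CHO cells for antagonist activity at prostaglandin E2 receptor EP1 subtype (Homo sapiens), read by FLIPR and calcium flux (a higher number here means a weaker inhibitor, a lower number a stronger inhibitor), the higher of the two numbers measured so far; compound 1 `Cc1ccc(S(=O)(=O)N(Cc2nnc(Cc3ccc(N(C)C)cc3)o2)c2cccc(Cl)c2C)cc1` gives 20 nM in this assay. Among the compounds with values here, the one step at this place, a 25-fold higher number from compound 1 to compound 2 (1.40 log units; beyond the scatter), was large. Compound 3 `Cc1ccc(S(=O)(=O)N(Cc2nnc(Cc3c(Cl)cccc3Cl)o2)c2cccc(Cl)c2C)cc1` differs from compound 2 by 2,6-dichlorophenyl in place of 3-fluorophenyl on a saturated chain carbon bound to an aromatic carbon. Within the data shown here, no measured step joins these two groups, so that single step shows only that the group at this place can move the number strongly, without telling which way. Compound 3 is therefore expected near 300 nM, between 60 nM and 2000 nM. The estimated step is a 1.7-fold lower number from compound 2 to compound 3 (0.22 log units; within the scatter).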

Compound 3, inhibition constant: 501 nM
Compound 3: the middle estimate sits 1.7-fold (0.22 log units) below what was measured; the measured number falls inside the stated range.
By their numbers in this assay, from the lowest: compound 1; then compounds 2 and 3 (each within the scatter of the next).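

In this assay, 2,6-dichlorophenyl in place of 3-fluorophenyl gives no change at the digits printed from compound 2 to compound 3 (within the scatter) and so leaves these two groups indistinguishable at this place. 2,6-Dichlorophenyl in place of 4-(dimethylamino)phenyl gives a 25-fold higher number from compound 1 to compound 3 (1.40 log units; beyond the scatter) and thus a second large step, leaving compound 1 the strongest inhibitor of the three. No measurement shown here explains either step.

The compounds shown leave open whether the dimethylamino group itself is what sets compound 1 apart. They also leave open how a phenyl carrying a pyrrolidine or a carboxylic acid would compare with 4-(dimethylamino)phenyl at this place.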